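Chain Length and Half-Life in a Guinea Pig Series

The source may hold more compounds than are shown below. What is called first, only, known or untested is meant among the compounds shown, and "the series" means these compounds.

Three amidine-bearing compounds built on one shared core were measured in an in vivo ADME assay on the whole organism (Cavia porcellus); a higher number here means that the compound lasts longer, a lower number that the compound disappears faster. Compound 1 `CC(C)C(NC(=O)c1ccc(C(=N)N)cc1)C(C)(C)C(=O)N1CCC(CC(=O)O)CC1` gives 0.8 h, compound 2 `CCCCC(NC(=O)c1ccc(C(=N)N)cc1)C(C)(C)C(=O)N1CCC(CC(=O)O)CC1` gives 1.03 h, and compound 3 `CC(C)CC(NC(=O)c1ccc(C(=N)N)cc1)C(C)(C)C(=O)N1CCC(CC(=O)O)CC1` gives 0.917 h. The step of a 1.3-fold higher number from compound 1 to compound 2 (0.11 log units; within the scatter) and the step of a 1.1-fold higher number from compound 1 to compound 3 (0.06 log units; within the scatter) both stay within the scatter, as does a 1.1-fold lower number from compound 2 to compound 3 (0.05 log units; within the scatter).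

Compound 4 `CCCCCC(NC(=O)c1ccc(C(=N)N)cc1)C(C)(C)C(=O)N1CCC(CC(=O)O)CC1` has not been measured. Its difference from compound 3 is butyl in place of isopropyl on a saturated chain carbon, two bonds along the chain from an amide-type nitrogen. The same kind of change was already made from compound 1 to compound 2, namely (butyl in place of isopropyl on a saturated chain carbon bound to an amide-type nitrogen and a saturated chain carbon), where it gave a 1.3-fold higher number from compound 1 to compound 2 (0.11 log units; within the scatter). The two cores differ by isobutyl in place of isopropyl on a saturated chain carbon bound to an amide-type nitrogen and a saturated chain carbon, and the place of the change is not identical: on a saturated chain carbon bound to an amide-type nitrogen and a saturated chain carbon in one case, on a saturated chain carbon, two bonds along the chain from an amide-type nitrogen in the other.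

On this basis the step from compound 3 to compound 4 is expected to be a 1.3-fold higher number from compound 3 to compound 4 (0.10 log units; within the scatter), resting on the earlier 1.3-fold higher number from compound 1 to compound 2 (0.11 log units; within the scatter). Compound 4 is therefore estimated at 1.15 h, with a range from 0.7 h to 1.9 h.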

Compound 4, half-life: 0.517 h
Estimate against measurement, compound 4: 2.2-fold (0.35 log units) above; the measured number lies below the stated range.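

In this assay, among these compounds, all three new steps lie within the scatter, so compound 4 cannot be ranked against any of the earlier compounds (a 1.8-fold lower number from compound 3 to compound 4 (0.25 log units; within the scatter)), (a 2.0-fold lower number from compound 2 to compound 4 (0.30 log units; within the scatter)) and (a 1.5-fold lower number from compound 1 to compound 4 (0.19 log units; within the scatter)). The data show neither that butyl in place of isopropyl gives the same result on both cores nor that its result depends on the core. Set side by side, the two readings of this change cannot be told apart, and a single pair on each core gives no firm rule for carrying it from one core to another: the same change on two cores in this assay, a 1.3-fold higher number (0.11 log units; within the scatter) from compound 1 to compound 2 and a 1.8-fold lower number (0.25 log units; within the scatter) from compound 3 to compound 4, 2.3-fold (0.36 log units) apart, within the scatter of two such steps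

All the groups shown at this place are open chains of carbon and hydrogen, which leaves open what a ring, a hydroxyl group or an amine on the chain would do to the half-life. From the compounds shown here alone, a chain longer than pentyl also remains open, as does whether any change at this place can move the number in this assay beyond the scatter.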